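The source may report more compounds than this note shows. Statements on the series, on what has been measured and on what is new or still open speak of the compounds shown alone.

Three compounds sharing the core of compound 1 `CC1CCN(c2c(S(=O)(=O)c3ccc(F)cc3)cnc3c(F)cccc23)CC1` were examined in an assay on isolated protein for displacement of a labelled ligand from metabotropic glutamate receptor 5 (Homo sapiens), with a stated time of 60 min, tested at 1 uM; on this read-out higher numbers stand for more inhibition at the one concentration tested (going by the name of the read-out) and lower numbers for less inhibition. Compound 1 gives 26%, the lowest of the three. Compound 2 `COc1ccc2ncc(S(=O)(=O)c3cccc(F)c3)c(N3CCC(C)CC3)c2c1` gives 68%, and compound 3 `COc1cccc(S(=O)(=O)c2cnc3ccc(F)cc3c2N2CCC(C)CC2)c1` gives 90%; both of these lie above compound 1 by more than the scatter. Among the compounds with values here, compounds 2 and 3 differ from compound 1 in more than one place, so no single-change step can be drawn from their values. Compound 4 `Cc1ccc(S(=O)(=O)c2cnc3c(F)cccc3c2N2CCC(C)CC2)cc1F` is not yet measured; it differs from compound 1 by 3-fluoro-4-methylphenyl in place of 4-fluorophenyl on a sulfonyl sulfur. Within the data shown here, with no measured single-change step to lean on, a modest upward step is expected a number 14 percentage points higher from compound 1 to compound 4 (beyond the scatter), of a size that may not clear the scatter. Compound 4 is therefore estimated to give 40% in this assay, within a range from 15% to 70%.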

Compound 4, a percentage reported as inhibition, at one concentration (the size of the read-out at that concentration, not a potency): 93%
Compound 4: the middle estimate sits 53 percentage points below what was measured; the measured number lies above the stated range.
By their numbers in this assay, from the lowest: compound 1; then compound 2; then compounds 3 and 4 (each within the scatter of the next).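

Within the data shown here, with the rest of compound 1 held fixed, 3-fluoro-4-methylphenyl in place of 4-fluorophenyl on a sulfonyl sulfur gives, in this assay, a number 67 percentage points higher from compound 1 to compound 4 (beyond the scatter) as the first single-change step in this set. It shows that the group at this place can move the read-out by a large amount on the shared core. Nothing measured here accounts for the size of this step. Still open, on these data alone, is whether the methyl or the fluorine of the new group carries the step, which a 4-methylphenyl group at this place would help to separate.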